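The source may hold more compounds than are shown below. What is called first, only, known or untested is meant among the compounds shown, and "the series" means these compounds.

Measured in a functional assay on QGY-7703 cells (Homo sapiens) for cytotoxicity, read by MTT assay, with a stated time of 24 h; a higher number here means a weaker inhibitor, a lower number a stronger inhibitor:
- compound 1 `CC(=O)Nc1ccc(S(=O)(=O)N2C/C(=C\c3ccccc3F)C(=O)/C(=C/c3ccccc3F)C2)cc1`: 5500 nM
- compound 2 `O=C1/C(=C/c2cccc([N+](=O)[O-])c2)CN(S(=O)(=O)c2ccc(F)cc2)C/C1=C\c1ccccc1F`: 14900 nM

Compound 2 carries the higher number of the two at 14900 nM. Its gap to compound 1 lies beyond the usual scatter, so compound 2 is the weaker inhibitor of this pair.

Next in the series is compound 3 `CC(=O)Nc1ccc(S(=O)(=O)N2C/C(=C\c3cccc([N+](=O)[O-])c3)C(=O)/C(=C/c3ccccc3F)C2)cc1`, which has acetamido in place of fluoro on an aromatic carbon, para to a large group (acetamido in place of fluoro on an aromatic carbon). The same difference reads 4-fluorophenyl to 4-acetamidophenyl.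

Among the measured compounds shown here, no pair of measured compounds isolates this change, so the data do not show its size directly. For the measured compounds named here, the only indication is that compound 1, which also carries the 4-acetamidophenyl group, reads 5500 nM, although it also differs from compound 2 elsewhere. A step towards a lower number in this assay is therefore expected, about as large as the scatter and no more certain than that. The expected change is a 2.0-fold lower number from compound 2 to compound 3 (0.30 log units; within the scatter). For compound 3 the estimate is 7500 nM, with an expected range of 3000 nM to 19000 nM.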

Compound 3, half-maximal inhibitory concentration: 7850 nM
Estimate against measurement, compound 3: 1.0-fold (0.02 log units) below; the range from low to high includes it.
By their numbers in this assay, from the lowest: compounds 1, 3 and 2 (each within the scatter of the next, the first and the last beyond it).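

In this assay, acetamido in place of fluoro on an aromatic carbon, para to a large group, can now be read as a single change: a 1.9-fold lower number from compound 2 to compound 3 (0.28 log units; within the scatter). This step lies within the scatter, so with the 3-nitrophenyl group held constant, these data do not separate 4-fluorophenyl from 4-acetamidophenyl at this position. The second single change, 3-nitrophenyl in place of 2-fluorophenyl on a double-bonded chain carbon bound to a double-bonded ring carbon, gives a 1.4-fold higher number from compound 1 to compound 3 (0.15 log units; within the scatter), also within the scatter, and no supporting data are available to explain either step.

As far as these compounds go, it remains open whether a different group at the para position, such as an amine, a carboxylic acid or a longer chain, would give a step beyond the scatter. From the compounds shown here alone, each change has also been read only once, against a single background, so it is unknown whether either step would hold with other groups elsewhere on the shared core.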